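This account rests on a few compounds, and the source may have more. Where it says the series, first, only, none or still open, it means among the compounds named here.

Compound 1 `COc1cc(Br)cc(/C=C/C(=O)c2ccccc2)c1O` gives 34.4% in an ADME assay on MCF-10A cells (Homo sapiens) for cytotoxicity, read by sulforhodamine B assay, with a stated time of 72 h, tested at 10 uM; on this read-out higher numbers stand for a stronger effect at the one concentration tested and lower numbers for a weaker effect. Its only companion so far, compound 2 `COc1cc(Br)cc(/C=C/C(=O)c2ccc(Cl)cc2)c1O`, gives 35.2% in this assay; the step of a number 0.8 percentage points higher from compound 1 to compound 2 (within the scatter) leaves the two indistinguishable. Compound 3 `COc1cccc(C(=O)/C=C/c2cc(Br)cc(OC)c2O)c1`, not yet measured, differs from compound 1 by methoxy in place of hydrogen on an aromatic carbon. Among the measured compounds shown here, the single measured step, chloro in place of hydrogen on an aromatic carbon, is the only substitution of this kind among the measured pair and stayed within scatter, so for compound 3 no step beyond scatter is expected in this assay, the expected step being a number 0.6 percentage points higher from compound 1 to compound 3 (within the scatter). Compound 3 is therefore estimated at 35%, within a range of 22% to 48%.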

Compound 3, a percentage reported as activity, at one concentration (the size of the read-out at that concentration, not a potency): 33.5%
Estimate against measurement, compound 3: 1.5 percentage points above, within the range that was stated.
By their numbers in this assay, from the lowest: compounds 3, 1 and 2 (each within the scatter of the next).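

In this assay, methoxy meta to a large group gives a number 0.9 percentage points lower from compound 1 to compound 3 (within the scatter) and so no shift that can be told from scatter. An entering group of 2 heavy atoms with 1 hydrogen-bond acceptor is thus accommodated at this place without a readable change in the cytotoxicity read-out. Alongside a number 0.8 percentage points higher from compound 1 to compound 2 (within the scatter) as the other step, two different substituents on this aromatic ring now leave the number where compound 1 has it.

From the compounds shown here alone, whether an amine or a carboxylic acid at this place would move the number beyond the scatter stays open. No measurement at hand speaks to what lies behind these small steps.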